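The source may report more compounds than this note shows. Statements on the series, on what has been measured and on what is new or still open speak of the compounds shown alone.

Among the compounds with values here, compound 2 `NNC(=O)c1nc(-c2ccccc2)n(-c2ccc(S(N)(=O)=O)cc2)n1` is one of two compounds measured in a functional assay on the whole organism for inhibition, with Rattus norvegicus as the target, read by paw edema, with stated times of 30 min and 5 h, at a dose of 0.28 mmol/kg by the oral route; on this read-out lower numbers stand for less inhibition and higher numbers for more inhibition at the one dose given (going by the name of the read-out). In that assay compound 2 gives 32%, the lower of the two numbers, while compound 1 `NS(=O)(=O)c1ccc(-n2nc(C(=O)NC3CCCCC3)nc2-c2ccccc2)cc1` gives 42%; the two lie within the scatter of each other, so no order between them can be read. Within the data shown here, the one step that connects them, a number 10 percentage points lower from compound 1 to compound 2 (within the scatter), exchanges amino for cyclohexyl on an amide-type nitrogen.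

Compound 3 `CC(C)NC(=O)c1nc(-c2ccccc2)n(-c2ccc(S(N)(=O)=O)cc2)n1` differs from compound 2 at that same position: isopropyl in place of amino on an amide-type nitrogen. Among the measured compounds shown here, the only step that bears on this change is a number 10 percentage points lower from compound 1 to compound 2 (within the scatter), which runs the opposite way, from an alkyl group to amino, and stayed within the scatter. A change from amino back to an alkyl group is therefore expected to give a step no larger than the scatter, if anything upward. Compound 3 is estimated to give 38%, between 25% and 52%, meaning an expected step of a number 6 percentage points higher from compound 2 to compound 3 (within the scatter).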

Compound 3, a percentage reported as inhibition, in the whole organism at one dose (the size of the read-out at that dose, not a potency): 43%
Compound 3: the middle estimate sits 5 percentage points below what was measured, and the stated range covers the measured number.
By their numbers in this assay, from the lowest: compounds 2, 1 and 3 (each within the scatter of the next, the first and the last beyond it).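

In this assay, the change at this amide-type nitrogen now gives a step beyond the scatter: a number 11 percentage points higher from compound 2 to compound 3 (beyond the scatter), with isopropyl in place of amino, whereas the earlier step from cyclohexyl to amino stayed within it. The two alkyl groups do not separate, as a number 1 percentage points higher from compound 1 to compound 3 (within the scatter) stays within the scatter, so this position distinguishes isopropyl from amino but not isopropyl from cyclohexyl. Nothing measured here accounts for the step.

The compounds shown leave open whether a benzyl group or a longer chain such as n-butyl on this nitrogen would read like the two alkyl groups or like amino. They also leave open how a carboxylic acid in place of the whole amide would read at this dose.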